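Adding a Protecting Group to a Hydrazide Tail

The source may hold more compounds than are shown below. What is called first, only, known or untested is meant among the compounds shown, and "the series" means these compounds.

Compound 2 `COc1cccc(-c2nc(SC)nc3sc(C(=O)NN)c(N)c23)c1` gives the smallest maximal response of the three compounds measured: in a functional assay on HEK293 cells for agonist activity at lutropin-choriogonadotropic hormone receptor (Homo sapiens), read by cAMP accumulation (on this read-out lower numbers stand for smaller maximal responses and higher numbers for larger maximal responses), compound 2 gives 8.5%. Compound 1 `COc1cccc(-c2nc(SC)nc3sc(C(=O)NCC#N)c(N)c23)c1` reaches 20.3%, and compound 3 `COc1cccc(-c2nc(SC)nc3sc(C(=O)NC(C)(C)C)c(N)c23)c1F` reaches 46.3%. Compound 4 `COc1cccc(-c2nc(SC)nc3sc(C(=O)NNC(=O)OC(C)(C)C)c(N)c23)c1` arises from compound 2 by one change: tert-butoxycarbonyl in place of hydrogen on an amine nitrogen. For the measured compounds named here, only one measured step bears on this, a number 11.8 percentage points lower from compound 1 to compound 2 (beyond the scatter), and it runs the opposite way: removing a group from the amide-type nitrogen lowered the response. Going by the values given here, compound 3 differs from compound 2 in two places, so its larger number gives no clean step. Compound 4 is expected to show a modest rise, a step of a number 13.5 percentage points higher from compound 2 to compound 4 (beyond the scatter). The estimate for compound 4 is 22%, expected to fall between 8% and 45%.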

Compound 4, largest response reached (reported as efficacy), in percent of the reference or control that the assay uses: 2.4%
For compound 4 the middle estimate is 19.6 percentage points above the measured one; the whole stated range lies above it.
By their numbers in this assay, from the lowest: compounds 4 and 2 (each within the scatter of the next); then compound 1; then compound 3.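

Placing tert-butoxycarbonyl on the amine nitrogen leaves the response essentially unchanged, with a number 6.1 percentage points lower from compound 2 to compound 4 (within the scatter), so adding this much bulk to the tail neither restores nor clearly removes the response. Measured against the cyanomethyl group, the (tert-butoxycarbonyl)amino group gives a number 17.9 percentage points lower from compound 1 to compound 4 (beyond the scatter), which places it with the amino group at the low end of this small set. Nothing measured here explains this result. Still open, on these data alone, is whether an acetyl group or a longer alkyl chain on this same nitrogen would also keep the response low.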